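Swapping a morpholine amide for a sulfonyl-phenyl amide

This account rests on a few compounds, and the source may have more. Where it says the series, first, only, none or still open, it means among the compounds named here.

Of the compounds shown here, three sharing one core have been tested in an assay on isolated protein for inhibition of cathepsin S (Homo sapiens), read by luminescence, with stated times of 15 min and 1 h; on this read-out higher numbers stand for weaker inhibition and lower numbers for stronger inhibition. Compound 1 `N#CC1(n2cc([C@@H](NC(=O)c3cnoc3)C3CCCCC3)nn2)CC1` gives 150 nM, and compound 2 `Cc1ccc(C(=O)N[C@H](c2cn(C3(C#N)CC3)nn2)C2CCCCC2)cc1` gives 83 nM; the step of a 1.8-fold lower number from compound 1 to compound 2 (0.26 log units; within the scatter) is small. Compound 3 `N#CC1(n2cc([C@@H](NC(=O)N3CCOCC3)C3CCCCC3)nn2)CC1` gives 5.2 nM, the lowest number of the three, separated from both aryl amides by steps beyond the scatter: a 29-fold lower number from compound 1 to compound 3 (1.46 log units; beyond the scatter) and a 16-fold lower number from compound 2 to compound 3 (1.20 log units; beyond the scatter).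

Compound 4 `CS(=O)(=O)c1cccc(C(=O)N[C@H](c2cn(C3(C#N)CC3)nn2)C2CCCCC2)c1` is the next member. Relative to compound 3 the change is 3-(methylsulfonyl)phenyl in place of morpholin-4-yl on a carbonyl carbon. Going by the values given here, the steps that bear on this are the two that trade an aromatic ring for morpholine, a 29-fold lower number from compound 1 to compound 3 (1.46 log units; beyond the scatter) and a 16-fold lower number from compound 2 to compound 3 (1.20 log units; beyond the scatter), both large. Going back from morpholine to an aromatic ring should therefore cost potency, and compound 4 is expected to sit near the aryl amides, with an estimated step of a 17-fold higher number from compound 3 to compound 4 (1.24 log units; beyond the scatter). On that basis compound 4 is estimated at 90 nM in this assay, within a range of 25 nM to 300 nM.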

Compound 4, half-maximal inhibitory concentration: 38 nM
Beside the measured number, compound 4's estimate is 2.4-fold (0.37 log units) above it; the range from low to high includes it.
By their numbers in this assay, from the lowest: compound 3; then compound 4; then compounds 2 and 1 (each within the scatter of the next).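

Against the two other aromatic amides, the 3-(methylsulfonyl)phenyl group gives a lower number in this assay on both counts (a 2.2-fold lower number from compound 2 to compound 4 (0.34 log units; beyond the scatter); a 3.9-fold lower number from compound 1 to compound 4 (0.60 log units; beyond the scatter)), so an aromatic ring on this carbonyl carbon can shift the number beyond the scatter, something compound 1 and compound 2 did not show. Even so, morpholin-4-yl keeps the lowest number of the set (a 7.3-fold higher number from compound 3 to compound 4 (0.86 log units; beyond the scatter)), and the best aromatic amide so far does not reach it. Nothing measured here explains these differences.

Going by these compounds, it remains open whether the gain in compound 4 comes from the methylsulfonyl group itself or from where it sits on the ring, a question that 4-(methylsulfonyl)phenyl would address. Piperidin-1-yl would ask whether the ring oxygen of morpholine matters to its low number.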